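A few compounds are considered here, and "the series" means these few. Any claim that something is new, unique, unknown or untested is made for them only; others in the source may bear on it.

Measured compounds:
- compound 1, `O=C1NCCc2nc(C#Cc3cccc(F)c3)sc21`, 290 nM
- compound 2, `O=C1NCCc2nc(C#Cc3ccccc3F)sc21`, 1500 nM
- compound 3, `CC1CC(C(=O)N2CCc3nc(C#Cc4ccccc4)sc3C2)C1`, 81 nM

All three were tested in an assay on HEK293 cells for positive allosteric modulation of metabotropic glutamate receptor 5 (Homo sapiens), read by FLIPR, with a stated time of 1 h; on this read-out higher numbers stand for an effect only at larger amounts of compound and lower numbers for an effect already at smaller amounts. Compound 3 stands at the lowest number of the three, so it acts at the smallest amount; its gap to compound 1, its nearest neighbour, is beyond the usual scatter, and its gap to compound 2, the furthest, is beyond the scatter as well. Compound 1 and compound 2 share everything except where the fluorine sits on their outer ring, yet their two values differ clearly.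

The next step keeps the shared core of compound 3 and exchanges the group attached to the carbonyl carbon, giving compound 4, `O=C(C1CCOCC1)N1CCc2nc(C#Cc3ccccc3)sc2C1`. The change is oxan-4-yl in place of 3-methylcyclobutyl on a carbonyl carbon: a four-membered ring of carbon only gives way to a six-membered ring holding one oxygen, which adds a hydrogen-bond acceptor but no charge. Among the measured compounds shown here, no measured pair shows this exchange, so no step between measured compounds can be leaned on; the estimate rests on compound 3 alone.

The expectation is a small move, if any, towards a higher number, a 1.9-fold higher number from compound 3 to compound 4 (0.27 log units; within the scatter), not confidently beyond the scatter. Compound 4 is therefore estimated at 150 nM, within a range from 50 nM to 500 nM.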

Compound 4, half-maximal effective concentration: 290 nM
The estimate for compound 4 lay 1.9-fold (0.29 log units) below the measured number, and the stated range covers the measured number.
By their numbers in this assay, from the lowest: compound 3; then compounds 1 and 4 (each within the scatter of the next); then compound 2.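

In this assay, placing oxan-4-yl instead of 3-methylcyclobutyl on the carbonyl carbon gives a 3.6-fold higher number from compound 3 to compound 4 (0.55 log units; beyond the scatter) and so marks the first measured change at this place among the compounds shown. The step lies beyond the usual scatter, which shows that the number responds to the group held by this carbonyl carbon, and that a six-membered ring holding one oxygen serves less well here than the four-membered ring of carbon only, though this rests on one pair. No measurement shown explains the shift, so the pair records its direction and size but not its origin.

The exchange alters ring size, the methyl group and the oxygen all at once, so the compounds shown leave open which of these changes accounts for the step. Cyclohexyl on the same carbonyl carbon would keep the six-membered ring without the oxygen, while cyclobutyl would keep the four-membered ring without the methyl group, and each could help to pull these contributions apart.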